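Cyclopropyl to 3-isopropoxypropyl on the amide of compound 1

This account rests on a few compounds, and the source may have more. Where it says the series, first, only, none or still open, it means among the compounds named here.

Measured compounds:
compound 1 `COc1cccc(OC)c1C(=O)Nc1c[nH]nc1C(=O)NC1CC1` — > 50000 nM
compound 2 `COc1cccc(OC)c1C(=O)Nc1c[nH]nc1C(=O)NC1CCN(C(=O)OC(C)(C)C)CC1` — > 50000 nM
compound 3 `CO[C@H]1CC[C@H](NC(=O)c2n[nH]cc2NC(=O)c2ccccc2C(F)(F)F)CC1` — 3300 nM

In an ADME assay on MRC5 cells (Homo sapiens) for inhibition, with a stated time of 72 h (a lower number here means that less compound is needed, a higher number that more compound is needed for the effect), compound 1 gives only a limit, > 50000 nM, and no number. Compound 2 likewise sits at a limit in this assay, > 50000 nM. Compound 3, which carries a different aryl amide on the shared core, gives a measured value of 3300 nM in this assay. Two of the three values therefore rest at the same limit (the limit of > 50000 nM in this assay, at which 2 of the 3 values shown sit).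

Compound 4 `COc1cccc(OC)c1C(=O)Nc1c[nH]nc1C(=O)NCCCOC(C)C` is not yet measured. It differs from compound 1 in one place (3-isopropoxypropyl in place of cyclopropyl on an amide-type nitrogen). Within the data shown here, no step between measured compounds that differ in one place is available, so the direction of this change cannot be read from a neighbour. Compound 2, which also keeps the dimethoxybenzamide of compound 1, stays at the limit, and that is the closest hint. The expected step of a number no higher from compound 1 to compound 4 (the limit leaves the size open) from compound 1 to compound 4 is accordingly none beyond the scatter. Compound 4 is expected to give about 50000 nM in this assay, within a range of 20000 nM to 150000 nM, most probably again reported only as a limit because compound 1 itself sits at > 50000 nM.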

Compound 4, half-maximal effective concentration: > 50000 nM
Compound 4: only a limit was reported (the forecaster's own chance of this, stated with the estimate: 70%); the middle value lies on the limit itself.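

In this assay, compound 1 and compound 4 both give only a limit, so no step can be read from compound 1 to compound 4: the limit of > 50000 nM in this assay, at which 3 of the 4 values shown sit. The compounds shown leave open whether 3-isopropoxypropyl in place of cyclopropyl on the amide-type nitrogen changes the value at all.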